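Replacing the bromophenyl group on a growth inhibitor

This account rests on a few compounds, and the source may have more. Where it says the series, first, only, none or still open, it means among the compounds named here.

- compound 1 `CN(C)C(=O)c1cc2cnc(Nc3ccc(NC(=O)C4(C(=O)Nc5ccc(Cl)cc5)CC4)cc3)nc2n1C1CCCC1`: 52.2%
- compound 2 `CN(C)C(=O)c1cc2cnc(Nc3ccc(NC(=O)C4(C(=O)Nc5ccc(Br)cc5)CC4)cc3)nc2n1C1CCCC1`: 27.6%

Going by the values given here, in a functional assay on NCI-H1299 cells (Homo sapiens) for inhibition, read by CCK-8 assay, with a stated time of 72 h, tested at 1 uM (on this read-out higher numbers stand for more inhibition of growth at the one concentration tested and lower numbers for less inhibition of growth), compound 2 gives 27.6%, the lower of the two numbers so far. The next molecule, compound 3 `CN(C)C(=O)c1cc2cnc(Nc3ccc(NC(=O)C4(C(=O)Nc5ccc(Cl)c(C(F)(F)F)c5)CC4)cc3)nc2n1C1CCCC1`, keeps the shared core and changes a single group: 4-chloro-3-(trifluoromethyl)phenyl in place of 4-bromophenyl on an amide-type nitrogen. In words, 4-chloro-3-(trifluoromethyl)phenyl comes in place of 4-bromophenyl on an amide-type nitrogen.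

Among the compounds with values here, only one measured step bears on this: a number 24.6 percentage points lower from compound 1 to compound 2 (beyond the scatter), with bromo in place of chloro on an aromatic carbon. Compound 3 carries chloro, as compound 1 with 52.2% does, so a rise in this assay is expected. Within the data shown here, the trifluoromethyl group is new, however, and no measured compound shows what it does, so the expected rise is set smaller than the measured step and its direction remains uncertain. The expected change is a number 16.4 percentage points higher from compound 2 to compound 3 (beyond the scatter). For compound 3 the estimated value is 44%, with an expected range from 20% to 68%.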

Compound 3, percent growth inhibition at one concentration: 39.5%
Compound 3: the middle estimate sits 4.5 percentage points above what was measured, within the range that was stated.
By their numbers in this assay, from the lowest: compound 2; then compound 3; then compound 1.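

In this assay, the trifluoromethyl group can finally be read on its own, and adding it to the chloro-bearing ring of compound 1 gives a number 12.7 percentage points lower from compound 1 to compound 3 (beyond the scatter), so this extra group does not leave the chloro compound's level of growth inhibition intact. Measured against the bromo compound, the full exchange of 4-bromophenyl for 4-chloro-3-(trifluoromethyl)phenyl on the amide-type nitrogen gives a number 11.9 percentage points higher from compound 2 to compound 3 (beyond the scatter), which shows that the aryl group here can carry more heavy atoms and still read higher than 4-bromophenyl, while both chloro-bearing compounds in this short series stand above the bromo one. Nothing measured here explains why these numbers move as they do.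

The compounds shown leave open what a trifluoromethyl group does on this ring without the chloro group, so the two substituents cannot yet be judged apart from each other in that setting. They also leave open whether a methoxy group, a nitrile or a plain unsubstituted phenyl ring on the same amide-type nitrogen would fall above or below these three numbers.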